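A few compounds are considered here, and "the series" means these few. Any claim that something is new, unique, unknown or untested is made for them only; others in the source may bear on it.

Measured in a functional assay on HUVEC cells (Homo sapiens) for inhibition; on this read-out lower numbers stand for stronger inhibition and higher numbers for weaker inhibition:
compound 1 `CN(c1ccc(NC(=O)Oc2ccccc2)cc1)c1ccnc(Nc2cccc(CS(C)(=O)=O)c2)n1`: 224 nM
compound 2 `CN(c1ccc(NC(=O)Nc2ccc(OC(F)(F)F)cc2)cc1)c1ccnc(Nc2ccc(S(N)(=O)=O)cc2)n1`: 37 nM

Compound 1 holds the higher of the two numbers, and compound 2 lies lower by a gap beyond the scatter. Going by the values given here, these two differ in more than one place, so no single-change step is available. Compound 3 `CN(c1ccc(NC(=O)Nc2c(Cl)cccc2Cl)cc1)c1ccnc(Nc2cccc(CS(C)(=O)=O)c2)n1` has (2,6-dichlorophenyl)amino in place of phenoxy on a carbonyl carbon. Compound 2 also has an arylamino group on its carbonyl carbon and gives 37 nM, so a moderate move to lower numbers in this assay is expected. The expected change is a 2.5-fold lower number from compound 1 to compound 3 (0.40 log units; beyond the scatter). The estimate for compound 3 is 90 nM, with an estimated range of 25 nM to 320 nM.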

Compound 3, half-maximal inhibitory concentration: 29 nM
For compound 3 the middle estimate is 3.1-fold (0.49 log units) above the measured one; measured number inside the range.
By their numbers in this assay, from the lowest: compounds 3 and 2 (each within the scatter of the next); then compound 1.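

In this assay, going by these compounds alone, (2,6-dichlorophenyl)amino in place of phenoxy on a carbonyl carbon gives a 7.7-fold lower number from compound 1 to compound 3 (0.89 log units; beyond the scatter) and provides the first single-change step. This shows that the group on this carbonyl carbon can shift the read-out beyond the scatter while the rest of compound 1 stays unchanged. No available evidence bears on the reason for this step.

As far as these compounds go, whether the step follows from the amino link or from the two chlorines remains open, and a plain phenylamino group on the same carbonyl carbon would separate these. From the compounds shown here alone, the effect of a benzylamino group at this place is also open.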